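Aryl-alkyne phenoxyacetic acids: substituent on the distal ring

The source may report more compounds than this note shows. Statements on the series, on what has been measured and on what is new or still open speak of the compounds shown alone.

Measured compounds:
compound 1, `CN(C)C(=O)c1cccc(C#Cc2cc(Cl)ccc2OCC(=O)O)c1` — 52 nM
compound 2, `O=C(O)COc1ccc(Cl)cc1C#Cc1ccccc1` — 108 nM
compound 3, `CS(=O)(=O)c1ccc(C#Cc2cc(Cl)ccc2OCC(=O)O)cc1` — 86 nM

All three were tested in an assay on CHO cells for displacement of a labelled ligand from prostaglandin D2 receptor 2 (Homo sapiens), read by scintillation counting; on this read-out higher numbers stand for weaker inhibition and lower numbers for stronger inhibition. Compound 2 carries the unsubstituted distal ring and gives the highest number of the three; compound 3 sits nearest to it, within the scatter, and compound 1 furthest, beyond the scatter.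

Compound 4, `O=C(O)COc1ccc(Cl)cc1C#Cc1cccc(C(F)(F)F)c1`, is not yet measured. Its change from compound 2 is trifluoromethyl in place of hydrogen on an aromatic carbon.

Going by the values given here, two measured steps bear on it, both being substituent changes on the same ring: a 2.1-fold higher number from compound 1 to compound 2 (0.32 log units; beyond the scatter) and a 1.3-fold lower number from compound 2 to compound 3 (0.10 log units; within the scatter). One substituent therefore gave a modest step, the other none beyond the scatter. For compound 4 a step of a 1.5-fold lower number from compound 2 to compound 4 (0.19 log units; within the scatter) is expected, toward a lower number. Compound 4 is estimated at 70 nM, with a range from 30 nM to 160 nM.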

Compound 4, inhibition constant: 92 nM
Beside the measured number, compound 4's estimate is 1.3-fold (0.12 log units) below it, within the range that was stated.
By their numbers in this assay, from the lowest: compounds 1, 3, 4 and 2 (each within the scatter of the next, the first and the last beyond it).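

In this assay, trifluoromethyl on an aromatic carbon, meta to a large group, gives a 1.2-fold lower number from compound 2 to compound 4 (0.07 log units; within the scatter) and so, like methylsulfonyl, adds no step beyond the scatter over the unsubstituted ring. Set against dimethylcarbamoyl, the same group gives a 1.8-fold higher number from compound 1 to compound 4 (0.25 log units; within the scatter) and is not resolved from it, even though dimethylcarbamoyl alone stands beyond the scatter from hydrogen. Nothing shown here bears on the reason for these small steps.

Open, on these data alone, is whether an amine, a carboxylic acid or a longer chain in this place would give a larger step in either direction.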